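Swapping Methyl for Fluoro on the Shared Core

The source may hold more compounds than are shown below. What is called first, only, known or untested is meant among the compounds shown, and "the series" means these compounds.

Measured compounds:
- Compound 1 `[N-]=[N+]=N[C@@H]1C(n2ccc(=O)[nH]c2=O)[Se][C@H](CO)[C@H]1O`; in a functional assay on SNU-638 cells (Homo sapiens) for cytotoxicity, read by sulforhodamine B assay (on this read-out higher numbers stand for weaker inhibition and lower numbers for stronger inhibition), compound 1 gives > 100000 nM, which is a limit of the assay and not a number.
- Compound 2 `Cc1cn(C2[Se][C@H](CO)[C@@H](O)[C@@H]2N=[N+]=[N-])c(=O)[nH]c1=O`; in this assay compound 2 gives > 100000 nM, again a limit of the assay and not a number.

Compound 2 therefore stands at the limit, with no measured number of its own. Among the compounds with values here, the one measured step, from compound 1 to compound 2, is a step that the two limits leave unreadable from compound 1 to compound 2, a change of methyl in place of hydrogen on an aromatic carbon whose size cannot be read because of the limit of > 100000 nM in this assay, at which 2 of the 2 values shown sit.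

Compound 3 `[N-]=[N+]=N[C@@H]1C(n2cc(F)c(=O)[nH]c2=O)[Se][C@H](CO)[C@H]1O` differs from compound 2 by fluoro in place of methyl on an aromatic carbon. Within the data shown here, the only step that bears on this change is the unreadable one above, so no size or direction can be expected for this assay beyond the scatter; compound 3 is expected to stay at the limit as well. The expected step from compound 2 to compound 3 is a number no higher from compound 2 to compound 3 (the limit leaves the size open). For compound 3 the estimate is 100000 nM, within a range from 30000 nM to 300000 nM.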

Compound 3, half-maximal inhibitory concentration: > 100000 nM
Compound 3: no number, only a limit (the forecaster's own chance of this, stated with the estimate: 80%); the middle value sits exactly at the limit.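

The steps among compound 1, compound 2 and compound 3 cannot be read, because all three give only a limit of the assay and not a number: the limit of > 100000 nM in this assay, at which 3 of the 3 values shown sit.

On these data alone, how hydrogen, methyl and fluoro on this aromatic carbon compare in this assay remains open, as does whether any compound on the shared core would give a measurable number.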